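A few compounds are considered here, and "the series" means these few. Any claim that something is new, unique, unknown or untested is made for them only; others in the source may bear on it.

Two compounds have numbers in a functional assay on HeLa cells for antagonist activity at 5-hydroxytryptamine receptor 6 (Homo sapiens), read by cAMP accumulation and immunoassay; on this read-out higher numbers stand for weaker inhibition and lower numbers for stronger inhibition. Compound 1 `O=S(=O)(Cc1ccc(Cl)s1)c1cn(C2CCNC2)c2ncccc12` gives 11 nM, and compound 2 `O=S(=O)(c1ccc(Cl)cc1)c1cn(C2CCCNC2)c2ncccc12` gives 682 nM, the higher of the two numbers, a gap beyond the scatter. Compound 3 `CCN1CCCC(n2cc(S(=O)(=O)c3ccc(Cl)cc3)c3cccnc32)C1` differs from compound 2 by ethyl in place of hydrogen on an amine nitrogen in a ring. Among the measured compounds shown here, no measured pair shows this change, so its size is not known from these data. Compound 3 is expected to show a step of a 1.4-fold lower number from compound 2 to compound 3 (0.13 log units; within the scatter) that stays within the scatter. The estimate for compound 3 is 500 nM, between 150 nM and 2000 nM.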

Compound 3, half-maximal inhibitory concentration: 70 nM
Estimate against measurement, compound 3: 7.1-fold (0.85 log units) above; measured number outside the range, below it.
By their numbers in this assay, from the lowest: compound 1; then compound 3; then compound 2.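

In this assay, ethyl in place of hydrogen on the amine nitrogen of the six-membered ring gives a 9.7-fold lower number from compound 2 to compound 3 (0.99 log units; beyond the scatter) and so strengthens inhibition beyond the scatter. Among the compounds shown here, this is the first pair that differs in one place, and it shows that this nitrogen accepts a substituent, with 1-ethylpiperidin-3-yl the better of the two groups. Nothing given here accounts for the size of this step.

Going by these compounds, whether methyl, propyl or a longer chain on this nitrogen would do as well remains open. So does whether ethyl would give a similar step on the ring amine of compound 1.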